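Ester chain length across three measured analogs

The source may hold more compounds than are shown below. What is called first, only, known or untested is meant among the compounds shown, and "the series" means these compounds.

Measured so far:
- compound 1 `CCOC(=O)C1=C(C)NC(C)=C(C(=O)OCC)C1c1csc(-c2ccc(Cl)cc2)n1`: 3650 nM
- compound 2 `CC1=C(C(=O)OC(C)C)C(c2csc(-c3ccc(Cl)cc3)n2)C(C(=O)OC(C)C)=C(C)N1`: 37200 nM
- compound 3 `CC1=C(C(=O)OC(C)c2ccccc2)C(c2csc(-c3ccc(Cl)cc3)n2)C(C(=O)OC(C)c2ccccc2)=C(C)N1`: 400000 nM

In an assay on isolated protein for antagonist activity at Voltage-dependent L-type calcium channel subunit alpha-1C (Cavia porcellus), with a stated time of 15 min (on this read-out lower numbers stand for stronger inhibition and higher numbers for weaker inhibition), compound 1 holds the lowest of the three numbers. Compound 2 stands higher, beyond the scatter, and compound 3 stands higher still, also beyond the scatter. Going by the values given here, both of these differ from compound 1 in more than one place, so no single-site step between measured compounds is available; what the numbers show is that the two bulkier ester pairs go with weaker inhibition, and nothing more.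

The unmeasured compound 4 `CCCOC(=O)C1=C(C)NC(C)=C(C(=O)OCC)C1c1csc(-c2ccc(Cl)cc2)n1` takes a smaller step from compound 1: methyl in place of hydrogen on a saturated chain carbon, two bonds along the chain from an oxygen next to a carbonyl group. Only one of the two ester chains grows, and by a single carbon. The measured compounds give no direct read on such a change. The expected step from compound 1 to compound 4 in this assay is small, toward a somewhat higher number or none beyond the scatter. On that basis compound 4 is expected to give 4500 nM, with a range from 1500 nM to 14000 nM. Taken as a step, the expectation is a 1.2-fold higher number from compound 1 to compound 4 (0.09 log units; within the scatter).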

Compound 4, half-maximal inhibitory concentration: 4090 nM
The estimate for compound 4 lay 1.1-fold (0.04 log units) above the measured number; low and high end bracket the measured number.
By their numbers in this assay, from the lowest: compounds 1 and 4 (each within the scatter of the next); then compound 2; then compound 3.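

In this assay, the series gains its first single-site step: methyl in place of hydrogen on a saturated chain carbon, two bonds along the chain from an oxygen next to a carbonyl group, turning ethyl into propyl on one ester chain, gives a 1.1-fold higher number from compound 1 to compound 4 (0.05 log units; within the scatter). Compounds 1 and 4 therefore cannot be told apart on this read-out, so this single change on one ester chain does not carry the number beyond the usual scatter. No independent measurement on the compounds shown bears on why this is so.

Going by these compounds, compounds 2 and 3 differ from compound 1 in more than one place, so it remains open what a single change on one ester chain contributes to their numbers, and whether the same methyl on the second ester chain would also stay within the scatter. Also open, on these data alone, is how far this position accepts further change, for example a butyl chain or a propyl chain ending in an amine or a carboxylic acid.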